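From 2,6-Dichlorophenyl to 2-Methoxyphenyl: An Untested Swap

The source may report more compounds than this note shows. Statements on the series, on what has been measured and on what is new or still open speak of the compounds shown alone.

compound 1 `Nc1ccccc1NC(=O)c1ccc(CNC(=O)c2n[nH]cc2NC(=O)c2ccccc2Cl)cc1`: 900 nM
compound 2 `Nc1ccccc1NC(=O)c1ccc(CNC(=O)c2n[nH]cc2NC(=O)c2ccccc2)cc1`: 1660 nM
compound 3 `Nc1ccccc1NC(=O)c1ccc(CNC(=O)c2n[nH]cc2NC(=O)c2c(Cl)cccc2Cl)cc1`: 710 nM

These values come from a functional assay on HCT-116 cells (Homo sapiens) for inhibition, read by CCK-8 assay, with a stated time of 72 h (a higher number here means a weaker inhibitor, a lower number a stronger inhibitor), and the three compounds differ only in the aromatic group on a carbonyl carbon. Compound 3 sits level with its nearest neighbour, with a 1.3-fold lower number from compound 1 to compound 3 (0.10 log units; within the scatter) as the gap, and stands clear of the other, with a 2.3-fold lower number from compound 2 to compound 3 (0.37 log units; beyond the scatter) as the gap.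

The unmeasured compound 4 `COc1ccccc1C(=O)Nc1c[nH]nc1C(=O)NCc1ccc(C(=O)Nc2ccccc2N)cc1` carries 2-methoxyphenyl in place of 2,6-dichlorophenyl on a carbonyl carbon. Going by the values given here, no measured compound has a methoxy group, so the only guides are the steps that alter chloro on this aromatic group. One of them is a 1.8-fold higher number from compound 1 to compound 2 (0.27 log units; within the scatter), and the largest of the three, quoted above, is still modest. No step beyond the scatter is therefore expected in this assay, and the expected move is a 1.4-fold higher number from compound 3 to compound 4 (0.15 log units; within the scatter). For compound 4 the estimated value is 1000 nM, with an expected range from 450 nM to 2200 nM.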

Compound 4, half-maximal inhibitory concentration: 3680 nM
The estimate for compound 4 lay 3.7-fold (0.57 log units) below the measured number; the measured number lies above the stated range.
By their numbers in this assay, from the lowest: compounds 3, 1 and 2 (each within the scatter of the next, the first and the last beyond it); then compound 4.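

In this assay, this position on the carbonyl carbon proves sensitive to which group it carries, as the change to methoxy gives a clear loss of activity, with a 5.2-fold higher number from compound 3 to compound 4 (0.71 log units; beyond the scatter) and a 4.1-fold higher number from compound 1 to compound 4 (0.61 log units; beyond the scatter). Going by these compounds alone, compound 4 is also weaker than the compound with plain phenyl, with a 2.2-fold higher number from compound 2 to compound 4 (0.35 log units; beyond the scatter), so here methoxy in place of hydrogen lowers activity, whereas the earlier compounds showed no such loss when chloro replaced hydrogen. Adding a group at this place therefore does not by itself preserve activity, and nothing available accounts for the gap between methoxy and chloro.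

On these data alone, it remains open whether 2-methylphenyl, 2-fluorophenyl or 2-hydroxyphenyl would fall with the chloro compounds or with compound 4. Whether 2,6-dimethoxyphenyl would behave like 2-methoxyphenyl or like 2,6-dichlorophenyl is also unresolved.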